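Removing one methoxy group from a weak aryl-acrylic acid

The compounds below may be only part of what the source reports. "The series", "measured", "known", "first", "only" and "open" are said of these compounds alone.

The three measured compounds share a core carrying an acetylated indole and a benzyloxy group, and differ only in the aryl ring on the double-bonded chain carbon. Compound 1 `COc1cc(OC)cc(/C(=C\c2cn(C(C)=O)c3ccc(OCc4ccccc4)cc23)C(=O)O)c1` carries a 3,5-dimethoxyphenyl there; in a functional assay on LNCaP cells (Homo sapiens) for cytotoxicity, read by MTT assay, with a stated time of 72 h (a higher number here means a weaker inhibitor, a lower number a stronger inhibitor), compound 1 gives 26100 nM. Compound 2 `CC(=O)n1cc(/C=C(/C(=O)O)c2ccc(Cl)cc2)c2cc(OCc3ccccc3)ccc21` carries a 4-chlorophenyl. In this assay compound 2 gives only a limit, > 100000 nM. Compound 3 `COc1ccc(/C(=C\c2cn(C(C)=O)c3ccc(OCc4ccccc4)cc23)C(=O)O)cc1OC` carries a 3,4-dimethoxyphenyl. In this assay compound 3 likewise gives only a limit, > 100000 nM, so its standing can be said only as lying at the weak end of what was measured, where (the limit of > 100000 nM in this assay, at which 2 of the 3 values shown sit). The measured steps are an at least 3.8-fold higher number from compound 1 to compound 2 (0.58 log units; beyond the scatter) and an at least 3.8-fold higher number from compound 1 to compound 3 (0.58 log units; beyond the scatter), both showing that moving away from the 3,5-dimethoxy pattern costs potency; the step that the two limits leave unreadable from compound 2 to compound 3 cannot be read.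

Compound 4 `COc1ccc(/C(=C\c2cn(C(C)=O)c3ccc(OCc4ccccc4)cc23)C(=O)O)cc1` is not yet measured. It differs from compound 3 by hydrogen in place of methoxy on an aromatic carbon. Going by the values given here, no measured step touches the loss of a single methoxy group, so the direction is open. Compound 4 is expected to remain close to the limit, a step of a number no higher from compound 3 to compound 4 (the limit leaves the size open). The estimate for compound 4 in this assay is 100000 nM, between 25000 nM and 400000 nM.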

Compound 4, half-maximal inhibitory concentration: 85000 nM
Beside the measured number, compound 4's estimate is 1.2-fold (0.07 log units) above it; the measured number falls inside the stated range.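

In this assay, hydrogen in place of the methoxy group ortho to a methoxy group gives an at least 1.1-fold lower number from compound 3 to compound 4 (0.07 log units; that floor lies within the scatter), so the data show no real gain from this change, although the floor does not fix its true size. Methoxy in place of chloro on the same kind of ring gives an at least 1.1-fold lower number from compound 2 to compound 4 (0.07 log units; that floor lies within the scatter), again only a floor that stays within the scatter, so neither swap separates these rings from one another. Going by these compounds alone, the new measured number does allow the first step with exact values at both ends, a 3.3-fold higher number from compound 1 to compound 4 (0.51 log units; beyond the scatter), which puts a modest size on the move from the 3,5-dimethoxyphenyl ring to the 4-methoxyphenyl ring, where earlier steps gave only a lower bound.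

As far as these compounds go, how far compound 4 truly lies from compound 3 stays open, since compound 3 is a limit and not a number, as is compound 2: the limit of > 100000 nM in this assay, at which 2 of the 4 values shown sit. Also open is whether a hydroxy group or an amine on that aromatic carbon, in place of the hydrogen of compound 4, would move the number beyond the scatter.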